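The compounds below may be only part of what the source reports. "The series", "measured", "known", "first", "only" and "open" are said of these compounds alone.

Measured so far in a physicochemical assay for metabolic stability, read by HPLC and mass spectrometry, in phosphate buffer, at 37 degrees C, at pH 7.4; on this read-out higher numbers stand for a longer-lived compound and lower numbers for a shorter-lived compound:
- compound 1 `CC(C)(O/N=C(\C(=O)N[C@@H]1C(=O)N(S(=O)(=O)O)[C@@H]1CNC(=O)CN)c1csc(N)n1)C(=O)O`: 149 h
- compound 2 `CN(C[C@@H]1[C@H](NC(=O)/C(=N\OC(C)(C)C(=O)O)c2csc(N)n2)C(=O)N1S(=O)(=O)O)C(=O)CN`: 212 h
- compound 3 `CC(C)(O/N=C(\C(=O)N[C@@H]1C(=O)N(S(=O)(=O)O)[C@@H]1CN1CCC1=O)c1csc(N)n1)C(=O)O`: > 1000 h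

Compound 3 reads > 1000 h, which is a limit of the assay and not a number.

The next compound to read is compound 4 `CC(C)(O/N=C(\C(=O)N[C@@H]1C(=O)N(S(=O)(=O)O)[C@@H]1CN1CCCC1=O)c1csc(N)n1)C(=O)O`. The change is 2-oxopyrrolidin-1-yl in place of 2-oxoazetidin-1-yl on a saturated chain carbon bound to a saturated ring carbon, with 2-oxopyrrolidin-1-yl in place of 2-oxoazetidin-1-yl on a saturated chain carbon bound to a saturated ring carbon.

Two measured steps act at this same place, and both end in 2-oxoazetidin-1-yl. They are an at least 6.7-fold higher number from compound 1 to compound 3 (0.82 log units; beyond the scatter) and an at least 4.7-fold higher number from compound 2 to compound 3 (0.67 log units; beyond the scatter), each beyond the scatter. The remaining step, a 1.4-fold higher number from compound 1 to compound 2 (0.15 log units; within the scatter), stays within the scatter. Among the measured compounds shown here, no measured step exchanges one of these ring groups for the other, so the data give no direction for this change. No step beyond the scatter is therefore expected in this assay, and the reading may again be only a limit.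

The expected change is a number no higher from compound 3 to compound 4 (the limit leaves the size open).

Compound 4 is estimated at 1000 h, with an expected range of 350 h to 3000 h.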

Compound 4, half-life: > 1000 h
Compound 4: no number, only a limit; the forecaster's own chance of this, stated with the estimate: 50%; the middle value sits exactly at the limit.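

In this assay, on a saturated chain carbon bound to a saturated ring carbon, 2-oxopyrrolidin-1-yl gives an at least 6.7-fold higher number from compound 1 to compound 4 (0.82 log units; beyond the scatter) and an at least 4.7-fold higher number from compound 2 to compound 4 (0.67 log units; beyond the scatter). The separation from the open-chain amide groups of compound 1 and compound 2 is therefore no longer confined to the 2-oxoazetidin-1-yl of compound 3, although only these two ring groups are shown. The step from compound 3 to compound 4 cannot be read, and the two ring groups stay unranked: the limit of > 1000 h in this assay, at which 2 of the 4 values shown sit.

Which of the two ring groups gives the longer half-life in this assay remains open. Also open, from the compounds shown here alone, is whether 2-oxopiperidin-1-yl, or a simple amine or carboxylic acid at the same place, would reach the same limit.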